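A Dimethoxyphenyl Replaces a Dichlorophenyl on the Ring Nitrogen

The source may hold more compounds than are shown below. What is called first, only, known or untested is meant among the compounds shown, and "the series" means these compounds.

Measured compounds:
compound 1 `COc1ccc(-c2cs/c(=N\NC(=O)c3ccc(O)cc3)n2-c2ccc(OC)cc2OC)cc1` — < 100000 nM
compound 2 `O=C(N/N=c1\scc(-c2ccc(Cl)cc2)n1-c1ccc(Cl)cc1Cl)c1ccc(O)cc1` — < 100000 nM

Of the compounds shown here, two have been tested in a functional assay on SF-295 cells (Homo sapiens) for cytotoxicity, read by sulforhodamine B assay, with a stated time of 48 h; on this read-out lower numbers stand for higher toxicity in this test and higher numbers for lower toxicity in this test. Compound 1 `COc1ccc(-c2cs/c(=N\NC(=O)c3ccc(O)cc3)n2-c2ccc(OC)cc2OC)cc1` returned only a limit, < 100000 nM. Compound 2 `O=C(N/N=c1\scc(-c2ccc(Cl)cc2)n1-c1ccc(Cl)cc1Cl)c1ccc(O)cc1` also returned only a limit, < 100000 nM. Both results sit at the limit of < 100000 nM in this assay, at which 2 of the 2 values shown sit, so neither compound carries a number and compound 2 stands at the same limit as compound 1, with nothing to separate them.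

Compound 3 `COc1ccc(-n2c(-c3ccc(Cl)cc3)cs/c2=N\NC(=O)c2ccc(O)cc2)c(OC)c1` has not yet been measured. It differs from compound 2 in one place: 2,4-dimethoxyphenyl in place of 2,4-dichlorophenyl on an aromatic nitrogen, in words 2,4-dimethoxyphenyl in place of 2,4-dichlorophenyl on an aromatic nitrogen. Within the data shown here, no step between measured compounds exists to guide the size of this change, and compound 1, which also carries a 2,4-dimethoxyphenyl group, gave only a limit. Compound 3 is expected to show a step that the limit leaves unreadable from compound 2 to compound 3, nothing beyond the scatter. The estimated value for compound 3 is 50000 nM, in a range from 10000 nM to 100000 nM.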

Compound 3, concentration lethal to 50% of the cells: < 100000 nM
Compound 3: no number, only a limit (the forecaster's own chance of this, stated with the estimate: 70%); the middle value does not contradict the limit.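

Among these compounds, compound 3 gave only a limit, as did compound 1 and compound 2, so no step among them can be read: the limit of < 100000 nM in this assay, at which 3 of the 3 values shown sit. The compounds shown leave open whether 2,4-dimethoxyphenyl in place of 2,4-dichlorophenyl, or chloro in place of methoxy, changes the result in this assay at all.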